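The source may report more compounds than this note shows. Statements on the series, on what has been measured and on what is new or still open speak of the compounds shown alone.

The series shares one core, carrying an amide whose nitrogen substituent varies. Compound 1 `Cc1sc(C(=O)N[C@@H]2CCCC[C@@H]2N)cc1-c1cnn2cc(-c3cnn(C)c3)cnc12` gives 1.3 nM in an assay for inhibition of MAP/microtubule affinity-regulating kinase 3 (Homo sapiens), read by HTRF, with a stated time of 2 h; on this read-out higher numbers stand for weaker inhibition and lower numbers for stronger inhibition. Compound 2 `Cn1cc(-c2cnc3c(-c4csc(C(=O)N[C@@H]5CCC[C@@H]5O)c4)cnn3c2)cn1` gives 43 nM in this assay, and compound 3 `CCNC(=O)c1cc(-c2cnn3cc(-c4cnn(C)c4)cnc23)cs1` gives 129 nM in this assay. Among the three numbers, compound 3 stands highest, nearest to compound 2 and furthest from compound 1.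

Compound 4 `Cn1cc(-c2cnc3c(-c4csc(C(=O)N[C@@H]5CCC[C@@H]5N)c4)cnn3c2)cn1` differs from compound 3 at the amide-type nitrogen: a group of 6 heavy atoms (5 carbon, 1 nitrogen; one five-membered non-aromatic ring of carbon only) in place of a group of 2 heavy atoms (2 carbon; no ring), on an amide-type nitrogen. Among the compounds with values here, the one measured step that touches this position is a 3.0-fold higher number from compound 2 to compound 3 (0.48 log units; beyond the scatter), where ethyl took the place of 2-hydroxycyclopentyl. Compound 4 carries a five-membered ring with a nitrogen in place of the oxygen of compound 2, so that step is read in reverse as a guide for what the ring returns; compound 1, which also carries a ring bearing a nitrogen on the amide nitrogen together with other differences, sits at the low end of the series and suggests the return may go further than the plain reversal. Compound 4 is therefore expected to give a lower number than compound 3, with the expected step of a 16-fold lower number from compound 3 to compound 4 (1.21 log units; beyond the scatter). The estimate for compound 4 in this assay is 8 nM, within a range from 2 nM to 30 nM.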

Compound 4, half-maximal inhibitory concentration: 2 nM
Beside the measured number, compound 4's estimate is 4.0-fold (0.60 log units) above it; the range from low to high includes it.
By their numbers in this assay, from the lowest: compounds 1 and 4 (each within the scatter of the next); then compound 2; then compound 3.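

Within the data shown here, on the amide-type nitrogen, the amino-bearing five-membered ring in place of ethyl brings a 65-fold lower number from compound 3 to compound 4 (1.81 log units; beyond the scatter) in this assay, so this position can move the number much further than the one earlier step at it, a 3.0-fold higher number from compound 2 to compound 3 (0.48 log units; beyond the scatter) when ethyl replaced the hydroxy-bearing ring. Much of the gain depends on a single group on that ring rather than on the ring alone: amino in place of hydroxy on a saturated ring carbon gives a 22-fold lower number from compound 2 to compound 4 (1.33 log units; beyond the scatter) with the rest of the structure unchanged. Nothing available explains why the amino group and the hydroxy group differ so widely on this read-out.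

The compounds shown leave open how specific this result is to a plain amino group, since a dimethylamino group, an aminomethyl group or a carboxylic acid on the same ring carbon would each test that directly. The effect of ring size also stays unresolved, as compound 1 differs from compound 4 in more than one place and so cannot separate it, and the opposite stereochemistry on the ring remains untested among these compounds.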